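The compounds below may be only part of what the source reports. "The series", "measured", "known", "first", "only" and "open" are said of these compounds alone.

Measured so far in a functional assay (muscle tissue) with Cavia porcellus as the target; on this read-out lower numbers stand for an effect already at smaller amounts and higher numbers for an effect only at larger amounts of compound:
- compound 1 `COC(=O)C1=C(C)N=C(C)/C(=C(\O)OC)C1c1cccc(OC)c1`: 191 nM
- compound 2 `COC(=O)C1=C(C)N=C(C)/C(=C(\O)OC)C1c1ccccc1Cl`: 2.19 nM

Of these two numbers, the lower belongs to compound 2, at 2.19 nM, and compound 1 lies well above it. The next compound is compound 3 `COC(=O)C1=C(C)N=C(C)/C(=C(\O)OC)C1c1ccccc1N`, still unmeasured: amino in place of chloro on an aromatic carbon. In words, this is amino in place of chloro on an aromatic carbon, ortho to a large group.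

Among the measured compounds shown here, only one measured step bears on this change, and only indirectly: an 87-fold lower number from compound 1 to compound 2 (1.94 log units; beyond the scatter). That large step, from 3-methoxyphenyl to 2-chlorophenyl, changes both the group and its place. For the measured compounds named here, it shows that this assay can respond strongly to a change on this ring, but no measured pair compares chloro with amino directly. Compound 3 keeps the place of the group in compound 2, so a step of the full size seen from compound 1 is not assumed. A moderate move to a higher number is expected instead, and the estimated step is an 11-fold higher number from compound 2 to compound 3 (1.06 log units; beyond the scatter). For compound 3 the expected value is 25 nM, with an estimated range of 4 nM to 200 nM.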

Compound 3, half-maximal effective concentration: 39800 nM
For compound 3 the middle estimate is 1600-fold (3.20 log units) below the measured one, and the stated range ends below it.
By their numbers in this assay, from the lowest: compound 2; then compound 1; then compound 3.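

In this assay, the earlier step changed both the group and its place, whereas this one holds the place fixed, on an aromatic carbon ortho to a large group, and changes only the group. Amino in place of chloro gives an 18000-fold higher number from compound 2 to compound 3 (4.26 log units; beyond the scatter), so a group at this place does not by itself secure a low number, and the identity of the group alone can carry a very large change. The 2-aminophenyl compound also stands clearly on the far side of the 3-methoxyphenyl compound, with a 210-fold higher number from compound 1 to compound 3 (2.32 log units; beyond the scatter), which places compound 2 and compound 3 at opposite ends of these three compounds; no measurement shown bears on what lies behind this difference.

Going by these compounds, whether a methyl, a hydroxyl or a nitro group at this same place would lie nearer to compound 2 or to compound 3 stays open. For methoxy, the contributions of group and place also remain unseparated, since compound 1 differs from compound 2 in both.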